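A carbamoylmethyl swap at the cytotoxicity limit

The source may report more compounds than this note shows. Statements on the series, on what has been measured and on what is new or still open speak of the compounds shown alone.

Among the measured compounds shown here, compound 2 `CC[C@H](C)[C@H](NC(=O)OC(C)(C)C)C(=O)N(Cc1ccccc1)C1(C(=O)NCc2ccccc2)CCN(Cc2ccccc2)CC1` is one of only two compounds so far measured in an ADME assay on MDCK cells (Canis lupus familiaris) for cytotoxicity, read by microscopy, with a stated time of 72 h; on this read-out lower numbers stand for higher toxicity in this test and higher numbers for lower toxicity in this test. In this assay compound 2 reaches the reporting limit, > 100000 nM, which is a limit and not a number. Compound 1 `COC(=O)C[C@H](NC(=O)OC(C)(C)C)C(=O)N(Cc1ccccc1)C1(C(=O)NCc2ccccc2)CCN(Cc2ccccc2)CC1` likewise sits at a limit, giving > 100000 nM. For the measured compounds named here, the single measured step, a step that the two limits leave unreadable from compound 1 to compound 2, is left unreadable by the two limits, as the limit of > 100000 nM in this assay, at which 2 of the 2 values shown sit, records. Compound 3 `CC(C)(C)OC(=O)N[C@@H](CC(N)=O)C(=O)N(Cc1ccccc1)C1(C(=O)NCc2ccccc2)CCN(Cc2ccccc2)CC1` differs from compound 2 by carbamoylmethyl in place of sec-butyl on a saturated chain carbon bound to an amide-type nitrogen and a carbonyl carbon. Going by the values given here, no measured step offers a readable size that bears on this change, so compound 3 is expected to remain at the limit as well, with no step beyond the scatter. The estimated step of a number no higher from compound 2 to compound 3 (the limit leaves the size open) is expected to lie within the scatter. Compound 3 is therefore estimated at 100000 nM, with a range from 50000 nM to 300000 nM, and is most likely to be reported only as a limit.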

Compound 3, minimum cytotoxic concentration: > 100000 nM
Compound 3 was reported as a limit; the forecaster's own chance of this, stated with the estimate: 90%; the middle value sits exactly at the limit.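

Compound 3 gives > 100000 nM in this assay, which is a limit and not a number. Among the compounds shown here, no step among compound 1, compound 2 and compound 3 can be read: the limit of > 100000 nM in this assay, at which 3 of the 3 values shown sit. The compounds shown leave open whether any group at this place would give a readable value.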